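The source may report more compounds than this note shows. Statements on the series, on what has been measured and on what is new or still open speak of the compounds shown alone.

Compound 3 `Cc1cc(NC(=O)Nc2ccc(C(N)=O)cc2)c2ccccc2n1` belongs to a small set of compounds built on a shared core. In an ADME assay on Raji cells (Homo sapiens) for cytotoxicity, with a stated time of 72 h (on this read-out lower numbers stand for an effect already at smaller amounts and higher numbers for an effect only at larger amounts of compound), compound 3 gives > 25000 nM, which is a limit of the assay rather than a number. Compound 1 `Cc1cc(NC(=O)Nc2ccc(C(=O)O)cc2)c2ccccc2n1` gives > 25000 nM in this assay, also a limit. Compound 2 `Cc1cc(NC(=O)Nc2ccc(Cl)cc2)c2ccccc2n1` gives > 25000 nM in this assay, again a limit. All three measured values thus sit at the limit of > 25000 nM in this assay, at which 3 of the 3 values shown sit, and none of the steps between them can be read: a step that the two limits leave unreadable from compound 1 to compound 2, a step that the two limits leave unreadable from compound 1 to compound 3 and a step that the two limits leave unreadable from compound 2 to compound 3 are all of unreadable size. Compound 4 `Cc1cc(NC(=O)Nc2ccc(OC(F)(F)F)cc2)c2ccccc2n1` differs from compound 3 in one place: trifluoromethoxy in place of carbamoyl on an aromatic carbon. Within the data shown here, no measured step bears on this change, and the three limits give no direction to build on; the only guidance is that every compound so far has returned only a limit. Compound 4 is therefore expected to behave like them, with a step that the limit leaves unreadable from compound 3 to compound 4 that means no change beyond the scatter. Compound 4 is estimated at 35000 nM, in the range 10000 nM to 120000 nM, most likely reported again only as a limit.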

Compound 4, half-maximal effective concentration: 10000 nM
Compound 4: middle estimate off by 3.5-fold (0.54 log units), on the high side; low and high end bracket the measured number.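

In this assay, trifluoromethoxy on this aromatic carbon, para to a large group, is the first group shown to give a measured number rather than a limit, with an at least 2.5-fold lower number from compound 3 to compound 4 (0.39 log units; beyond the scatter) when it takes the place of carbamoyl. The same group gives an at least 2.5-fold lower number from compound 2 to compound 4 (0.39 log units; beyond the scatter) in place of chloro, and an at least 2.5-fold lower number from compound 1 to compound 4 (0.39 log units; beyond the scatter) in place of carboxy. The group at this position can therefore change the read-out, while the other three compounds stay at a limit: the limit of > 25000 nM in this assay, at which 3 of the 4 values shown sit.

On these data alone, the true size of these steps stays open, and the steps among compound 1, compound 2 and compound 3 cannot be read. The compounds shown also leave open whether a trifluoromethyl group, a methoxy group or a longer alkyl chain at this position would lower the number in the same way.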